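From 3-chlorophenyl to 2-chlorophenyl on compound 2

The compounds below may be only part of what the source reports. "The series", "measured", "known", "first", "only" and "open" are said of these compounds alone.

Measured values in an ADME assay on stomach for solubility, in simulated gastric fluid (a higher number here means a more soluble compound, a lower number a less soluble compound), follow.
Compound 1 `O=C(Nc1ccc(OC(F)(F)F)cc1)N1CCOC2(CCN(C(=O)c3cc(Cl)ccn3)CC2)C1` gives 90 ug/mL
Compound 2 `O=C(Nc1ccc(C(F)(F)F)cc1)N1CCOC2(CCN(C(=O)c3cccc(Cl)c3)CC2)C1` gives 26 ug/mL
Compound 3 `Cc1cnc(C(=O)N2CCC3(CC2)CN(C(=O)Nc2ccc(OC(F)(F)F)cc2)CCO3)cn1` gives 91 ug/mL

Compound 2 has the lowest number of the three, and compound 1 and compound 3 both lie above it beyond the scatter. Compound 4 `O=C(Nc1ccc(C(F)(F)F)cc1)N1CCOC2(CCN(C(=O)c3ccccc3Cl)CC2)C1` differs from compound 2 by a single change, (2-chlorophenyl in place of 3-chlorophenyl on a carbonyl carbon), with the same atoms joined differently. Going by the values given here, the only measured step, a 1.0-fold higher number from compound 1 to compound 3 (0.00 log units; within the scatter), exchanges other groups on the carbonyl carbon and stays within the scatter. Among the compounds with values here, no measured step exchanges 3-chlorophenyl for 2-chlorophenyl, so the guidance is weak. No change beyond the scatter is expected in this assay, and the expected step is a 1.2-fold higher number from compound 2 to compound 4 (0.09 log units; within the scatter). For compound 4 the estimated value is 32 ug/mL, with an expected range of 13 ug/mL to 80 ug/mL.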

Compound 4, solubility: 10 ug/mL
Compound 4: the middle estimate sits 3.2-fold (0.51 log units) above what was measured; the whole stated range lies above it.
By their numbers in this assay, from the lowest: compound 4; then compound 2; then compounds 1 and 3 (each within the scatter of the next).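

In this assay, 2-chlorophenyl in place of 3-chlorophenyl on a carbonyl carbon gives a 2.6-fold lower number from compound 2 to compound 4 (0.41 log units; beyond the scatter) with no atom gained or lost, so the place of the chlorine alone moves the number here. The earlier exchange on a carbonyl carbon, a 1.0-fold higher number from compound 1 to compound 3 (0.00 log units; within the scatter), showed no such movement. Nothing at hand accounts for this difference. The compounds shown leave open whether the same chlorine shift would carry over to the trifluoromethoxy compounds. They also leave open where an aminophenyl group on this carbonyl carbon would fall.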